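A few compounds are considered here, and "the series" means these few. Any claim that something is new, unique, unknown or untested is made for them only; others in the source may bear on it.

Measured so far:
compound 1 `O=C(NCc1ccc(S(=O)(=O)c2cccc(F)c2)cc1)c1cc2cnccc2[nH]1`: 11 nM in a functional assay on A2780 cells (Homo sapiens) for inhibition, read by sulforhodamine B assay, with a stated time of 72 h; a lower number here means a stronger inhibitor, a higher number a weaker inhibitor
compound 2 `O=C(NCc1ccc(S(=O)(=O)N2CCCCC2)cc1)c1cc2cnccc2s1`: 1600 nM in this assay
compound 3 `O=C(NCc1ccc(S(=O)(=O)c2ccccc2)cc1)c1ccc2nncn2c1`: a limit of the assay, > 10000 nM in this assay

Going by the values given here, compound 2 holds the highest of the two numbers in this assay; compound 1 sits a long way lower, beyond the scatter, though the two differ in more than one place and no single step is defined between them. For compound 3 only the limit of > 10000 nM in this assay, at which 1 of the 3 values shown sits, is known. Among the compounds with values here, none of the measured pairs differs in one place, so no measured step is available.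

Compound 4 `O=C(NCc1ccc(S(=O)(=O)N2CCCCC2)cc1)c1cc2ccncc2o1` differs from compound 2 on the carbonyl carbon: a group of 9 heavy atoms (7 carbon, 1 nitrogen, 1 oxygen; one five-membered aromatic ring with 1 hetero atom, one six-membered aromatic ring with 1 hetero atom) in place of a group of 9 heavy atoms (7 carbon, 1 nitrogen, 1 sulfur; one five-membered aromatic ring with 1 hetero atom, one six-membered aromatic ring with 1 hetero atom), on a carbonyl carbon. The change keeps ring size, ring count and hydrogen-bond acceptor count the same. The step from compound 2 to compound 4 in this assay is expected to be small, within or close to the scatter, with no firm direction. Compound 4 is estimated at 2000 nM in this assay, range 500 nM to 8000 nM, an expected step of a 1.3-fold higher number from compound 2 to compound 4 (0.10 log units; within the scatter).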

Compound 4, half-maximal inhibitory concentration: 29 nM
Beside the measured number, compound 4's estimate is 69-fold (1.84 log units) above it, outside the stated range (below it).
By their numbers in this assay, from the lowest: compound 1; then compound 4; then compound 2. At a limit, above all of these: compound 3.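

In this assay, going by these compounds alone, the group on the carbonyl carbon is the first place with a measured single-place step, and that step is large: a 55-fold lower number from compound 2 to compound 4 (1.74 log units; beyond the scatter). The two groups match in heavy-atom count, ring sizes and hydrogen-bond acceptor count, so those counts do not settle the value at this position; the exchange is also more than sulfur for oxygen, as the ring nitrogen lies elsewhere in the six-membered aromatic ring. No measurement shown here accounts for the step.

Still open, on these data alone, is which part of the exchange carries the step, the oxygen or the placement of the ring nitrogen. Also open, as far as these compounds go, is whether a methoxy group or a primary amine on this group would be tolerated at the carbonyl carbon, and whether the step holds with the piperidine sulfonamide replaced.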